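The source may hold more compounds than are shown below. What is called first, only, known or untested is meant among the compounds shown, and "the series" means these compounds.

Measured so far:
- compound 1, `Cc1ccccc1COc1ccc(N2CCC[C@H]2CC(=O)O)cc1`: 190 nM
- compound 2, `O=C(O)C[C@@H]1CCCN1c1ccc(Oc2ccccc2)cc1`: 560 nM
- compound 3, `O=C(O)C[C@@H]1CCCN1c1ccc(Oc2ccc(Cl)cc2Cl)cc1`: 360 nM

All numbers come from a functional assay on cells for agonist activity at Free fatty acid receptor 1 (Homo sapiens), read by FLIPR and calcium flux, with a stated time of 100 s; on this read-out lower numbers stand for an effect already at smaller amounts and higher numbers for an effect only at larger amounts of compound. Compound 3 gives the second highest of the three numbers, but its neighbours are close on both sides: a 1.6-fold lower number from compound 2 to compound 3 (0.19 log units; within the scatter), and a 1.9-fold higher number from compound 1 to compound 3 (0.28 log units; within the scatter). Neither of these separates compound 3 from compound 2 or compound 1 beyond the scatter. Going by the values given here, the only step that does stand out is a 2.9-fold higher number from compound 1 to compound 2 (0.47 log units; beyond the scatter), which swaps the benzyl-type group on the oxygen for a plain phenyl.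

Compound 4, `O=C(O)C[C@@H]1CCCN1c1ccc(Oc2ccccc2F)cc1`, is the next member to be measured in this assay . Relative to compound 3 the change is 2-fluorophenyl in place of 2,4-dichlorophenyl on an oxygen on an aromatic ring. The step that bears on it most directly is the one between the two phenyl-type ethers, a 1.6-fold lower number from compound 2 to compound 3 (0.19 log units; within the scatter), which lies within the scatter; compound 4 carries a phenyl variant that sits in the same family as compound 2 and compound 3. Among the compounds with values here, with only that step to go on, no change beyond the scatter is expected from compound 3 to compound 4, that is a 1.3-fold higher number from compound 3 to compound 4 (0.10 log units; within the scatter). For compound 4 the expected value in this assay is 450 nM, with a range of 200 nM to 1000 nM.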

Compound 4, half-maximal effective concentration: 150 nM
For compound 4 the middle estimate is 3.0-fold (0.48 log units) above the measured one; measured number outside the range, below it.
By their numbers in this assay, from the lowest: compounds 4, 1, 3 and 2 (each within the scatter of the next, the first and the last beyond it).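

In this assay, going by these compounds alone, the phenyl ethers now separate beyond the scatter: fluoro in place of hydrogen on an aromatic carbon gives the largest step so far within this group (a 3.7-fold lower number from compound 2 to compound 4 (0.57 log units; beyond the scatter)), and 2-fluorophenyl in place of 2,4-dichlorophenyl also registers (a 2.4-fold lower number from compound 3 to compound 4 (0.38 log units; beyond the scatter)), whereas the earlier replacement of phenyl by 2,4-dichlorophenyl stayed within the scatter. A directly attached aryl group on this oxygen therefore need not give a higher number than the 2-methylbenzyl group, as compound 4 cannot be told apart from compound 1 (a 1.3-fold lower number from compound 1 to compound 4 (0.10 log units; within the scatter)), while compound 2 could. No measurement at hand accounts for the result of the fluoro replacement.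

Going by these compounds, it remains open whether this result is specific to fluoro, since a 2-chlorophenyl, 2-methylphenyl or 2-methoxyphenyl group on the same oxygen would test that directly. Also open, on these data alone, is whether 2-fluorophenyl keeps its standing when the carboxylic acid of the shared core gives way to an amide or sits on a longer chain.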